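The source may report more compounds than this note shows. Statements on the series, on what has been measured and on what is new or still open speak of the compounds shown alone.

Measured so far:
Compound 1 `Cc1ccc(CCC(=O)N[C@@H](C(=O)N2CCC(c3ccc(Cl)cc3)CC2)C(C)C)cc1` gives 105 nM in an assay on THP-1 cells for displacement of a labelled ligand from C-C chemokine receptor type 1 (Homo sapiens); a higher number here means a weaker inhibitor, a lower number a stronger inhibitor.
Compound 2 `O=C(N[C@@H](C(=O)N1CCC(c2ccc(Cl)cc2)CC1)C1CCCCC1)c1ccccc1` gives 121 nM in this assay.

Compound 1 has the lower of the two numbers in this assay, but its nearest neighbour, compound 2, stands within the scatter of it, so the two cannot be told apart on these figures. For the measured compounds named here, no pair of measured compounds differs in a single place, so no measured step is available to lean on.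

The unmeasured compound 3 `CC(C)[C@@H](NC(=O)c1nc2ccccc2s1)C(=O)N1CCC(c2ccc(Cl)cc2)CC1` is reached from compound 1 by one change: 1,3-benzothiazol-2-yl in place of 2-(4-methylphenyl)ethyl on a carbonyl carbon. Both compound 1 and compound 2 carry an aromatic group on this carbonyl carbon and sit close together in this assay, which gives no reason to expect a large move. Compound 3 is therefore expected to land near compound 1, with a step of a 1.3-fold lower number from compound 1 to compound 3 (0.12 log units; within the scatter) that may not exceed the scatter. The estimate for compound 3 in this assay is 80 nM, with a range from 25 nM to 250 nM.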

Compound 3, half-maximal inhibitory concentration: 18 nM
Estimate against measurement, compound 3: 4.4-fold (0.65 log units) above, outside the stated range (below it).
By their numbers in this assay, from the lowest: compound 3; then compounds 1 and 2 (each within the scatter of the next).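

For the compounds shown here, on a carbonyl carbon whose other neighbours are amide-type nitrogen, 1,3-benzothiazol-2-yl in place of 2-(4-methylphenyl)ethyl gives a 5.8-fold lower number from compound 1 to compound 3 (0.77 log units; beyond the scatter) in this assay, so this position can respond to a change of group, which the earlier compounds, differing in more than one place, could not show. The change keeps the count of 9 heavy atoms and a six-membered aromatic ring of carbon only, while it brings in a five-membered aromatic ring with 2 hetero atoms and 2 hydrogen-bond acceptors. No measurement shown accounts for the step.

Several features change together in this one step, so the compounds shown leave open which of them goes with the lower number. From the compounds shown here alone, it also remains open how a 1,3-benzoxazol-2-yl group, with oxygen in place of sulfur, or a simple phenyl would behave on this carbonyl carbon.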